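A few compounds are considered here, and "the series" means these few. Any claim that something is new, unique, unknown or untested is made for them only; others in the source may bear on it.

Measured so far:
Compound 1 `COc1cc(Nc2ncnc3c(NC(=O)Nc4cc(F)cc(F)c4)cccc23)cc(OC)c1` gives 2630 nM.
Compound 2 `COc1cc(Nc2ncnc3c(NC(=O)Nc4ccc(F)cc4C(F)(F)F)cccc23)cc(OC)c1` gives 2970 nM.
Compound 3 `COc1cc(Nc2ncnc3c(NC(=O)Nc4ccc5c(c4)OCCO5)cccc23)cc(OC)c1` gives 2750 nM.

In a functional assay on RT-112 cells (Homo sapiens) for antiproliferative activity, read by MTT assay, with a stated time of 72 h (on this read-out lower numbers stand for stronger inhibition of growth and higher numbers for weaker inhibition of growth), the three compounds share one core and differ only in the aryl group on the amide-type nitrogen of the urea. Their numbers lie close together: the steps of a 1.0-fold higher number from compound 1 to compound 3 (0.02 log units; within the scatter) and a 1.1-fold lower number from compound 2 to compound 3 (0.03 log units; within the scatter) are both within the scatter, as is a 1.1-fold higher number from compound 1 to compound 2 (0.05 log units; within the scatter). Compound 3 therefore sits in the middle of a flat set.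

Compound 4 `COc1cc(Nc2ncnc3c(NC(=O)Nc4cccc(C(F)(F)F)c4F)cccc23)cc(OC)c1` carries 2-fluoro-3-(trifluoromethyl)phenyl in place of 2,3-dihydro-1,4-benzodioxin-6-yl on an amide-type nitrogen. Since swapping fluorinated phenyl groups for the benzodioxinyl group changed nothing beyond the scatter, the step of a 1.0-fold higher number from compound 3 to compound 4 (0.01 log units; within the scatter) is expected to be small. Compound 4 is estimated at 2800 nM, with a range from 1400 nM to 5600 nM.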

Compound 4, concentration for 50% growth inhibition: 471 nM
For compound 4 the middle estimate is 5.9-fold (0.77 log units) above the measured one, outside the stated range (below it).
By their numbers in this assay, from the lowest: compound 4; then compounds 1, 3 and 2 (each within the scatter of the next).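

At this position on the amide-type nitrogen, the aryl group can matter after all: in this assay, 2-fluoro-3-(trifluoromethyl)phenyl gives a 5.8-fold lower number from compound 3 to compound 4 (0.77 log units; beyond the scatter) and a 5.6-fold lower number from compound 1 to compound 4 (0.75 log units; beyond the scatter). The closest comparison is a 6.3-fold lower number from compound 2 to compound 4 (0.80 log units; beyond the scatter), since 4-fluoro-2-(trifluoromethyl)phenyl carries the same two substituents in a different arrangement. Having fluorine and trifluoromethyl on the phenyl ring is therefore not enough, and their arrangement goes with the gain.

Nothing available here bears on the reason for these steps. Also open, going by these compounds, is whether a chlorine or a nitrile in place of the trifluoromethyl would keep the gain.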